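A Carboxypyridyl Group in Place of Methylsulfonyl

A few compounds are considered here, and "the series" means these few. Any claim that something is new, unique, unknown or untested is made for them only; others in the source may bear on it.

Measured so far:
Compound 1 `O=C(CCc1ccc(-c2ccccc2)cc1)c1ncc(-c2ccncc2)o1` — 2.3 nM
Compound 2 `CS(=O)(=O)c1cnc(C(=O)CCc2ccc(-c3ccccc3)cc2)o1` — 1.2 nM

Among the measured compounds shown here, in an assay for inhibition of Fatty-acid amide hydrolase 1 (Rattus norvegicus) (a higher number here means a weaker inhibitor, a lower number a stronger inhibitor), compound 2 gives 1.2 nM, the lowest of the two numbers, but its only neighbour is compound 1, and the move a 1.9-fold lower number from compound 1 to compound 2 (0.28 log units; within the scatter) stays within the scatter, so the two compounds cannot be ranked. Compound 3 `O=C(O)c1cc(-c2cnc(C(=O)CCc3ccc(-c4ccccc4)cc3)o2)ccn1` has not yet been measured. It differs from compound 2 in one place: 2-carboxypyridin-4-yl in place of methylsulfonyl on an aromatic carbon. For the measured compounds named here, the one measured step that bears on this is the same swap read in reverse: exchanging pyridin-4-yl for methylsulfonyl at this carbon changed the number only within the scatter, which suggests this position tolerates different groups. Going by the values given here, the carboxylic acid now attached to the pyridine has no measured counterpart, so a modest loss is assumed as a precaution. For compound 3 a step of a 6.7-fold higher number from compound 2 to compound 3 (0.82 log units; beyond the scatter) is therefore expected, giving an estimated 8 nM, with a range from 2 nM to 40 nM.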

Compound 3, inhibition constant: 50 nM
The estimate for compound 3 lay 6.3-fold (0.80 log units) below the measured number; the whole stated range lies below it.
By their numbers in this assay, from the lowest: compounds 2 and 1 (each within the scatter of the next); then compound 3.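

Compound 1 and compound 2 suggested that this carbon, next to the ring oxygen, accepts quite different groups, but in this assay that tolerance has a limit (a 42-fold higher number from compound 2 to compound 3 (1.62 log units; beyond the scatter)). The clearest comparison is the pair that differs only by carboxy in place of hydrogen on an aromatic carbon (a 22-fold higher number from compound 1 to compound 3 (1.34 log units; beyond the scatter)). The pyridine ring alone therefore does not account for the loss, since compound 1 carries that ring too, and the large step appears only once the carboxy group is added, although no measurement here explains the size of that step.

As far as these compounds go, it remains open whether a methyl ester or a primary amide in place of the carboxylic acid would bring a similar loss. From the compounds shown here alone, the effect of moving the carboxy group to another carbon of the pyridine ring also remains open.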